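Ether substituent variation on the biaryl tail

A few compounds are considered here, and "the series" means these few. Any claim that something is new, unique, unknown or untested is made for them only; others in the source may bear on it.

Measured so far:
Compound 1 `CCOc1ccc(-c2ccc(N(C[C@@H](N)[C@@H](C)CC)C(=O)[C@@H]3C[C@H]3c3ccccc3)cc2)cc1`: in a functional assay for agonist activity at G protein-coupled receptor 88 (Homo sapiens), read by HTRF and cAMP accumulation (a lower number here means that less compound is needed, a higher number that more compound is needed for the effect), compound 1 gives 90 nM.
Compound 2 `CC[C@H](C)[C@H](N)CN(C(=O)[C@@H]1C[C@H]1c1ccccc1)c1ccc(-c2ccc(COC)cc2)cc1`: in this assay compound 2 gives 35 nM.

For the measured compounds named here, compound 2 stands as the lower of the two numbers; its only neighbour is compound 1, and the two are separated by the step of a 2.6-fold lower number from compound 1 to compound 2 (0.41 log units; beyond the scatter), a modest shift beyond the scatter.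

Compound 3 `CC[C@H](C)[C@H](N)CN(C(=O)[C@@H]1C[C@H]1c1ccccc1)c1ccc(-c2ccc(COC(C)(C)C)cc2)cc1` is not yet measured. It differs from compound 2 by tert-butyl in place of methyl on an oxygen on a saturated carbon. Going by the values given here, no measured step bears directly on this change. Among the compounds with values here, the single step on hand, a 2.6-fold lower number from compound 1 to compound 2 (0.41 log units; beyond the scatter), exchanges ethoxy for methoxymethyl on an aromatic carbon, which is a different change at a different place, and the series holds no pair that varies the alkyl on the ether oxygen of the methoxymethyl group. The direction and size of the new step therefore cannot be read from any precedent here. The expectation for compound 3 in this assay is a step of a 1.7-fold higher number from compound 2 to compound 3 (0.23 log units; within the scatter), a small rise that may well fall within the scatter, with wide uncertainty in both directions. Compound 3 is estimated at 60 nM, with a range from 20 nM to 200 nM.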

Compound 3, half-maximal effective concentration: 280 nM
Compound 3: middle estimate off by 4.7-fold (0.67 log units), on the low side; the whole stated range lies below it.
By their numbers in this assay, from the lowest: compound 2; then compound 1; then compound 3.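

In this assay, for the compounds shown here, the alkyl group on the ether oxygen matters: tert-butyl in place of methyl gives an 8.0-fold higher number from compound 2 to compound 3 (0.90 log units; beyond the scatter), the only measured change at this oxygen. The tail of compound 3 also compares unfavourably with the ethoxy tail, as (tert-butoxy)methyl in place of ethoxy on an aromatic carbon gives a 3.1-fold higher number from compound 1 to compound 3 (0.49 log units; beyond the scatter), so the lower number of compound 2 does not carry over to every (alkoxy)methyl group and depends on what sits on the oxygen. Nothing available accounts for the rise.

Going by these compounds, with only methyl and tert-butyl on this oxygen, the shape of the trend remains open: ethyl or isopropyl could give numbers close to that of compound 2, or the rise could build steadily from methyl to tert-butyl. On these data alone, it is also open whether the ether oxygen itself is needed, which a hydroxymethyl group, an aminomethyl group or a plain propyl chain at the same place on the tail would help to settle.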